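The compounds below may be only part of what the source reports. "The series", "measured", "known", "first", "only" and "open" are said of these compounds alone.

Notes on the series in a functional assay on brain (Rattus norvegicus, strain Wistar) for inhibition (a lower number here means a stronger inhibitor, a higher number a weaker inhibitor), starting from compound 1 `Cc1[nH]c(=O)n(C)c1-c1ccccc1`. Compound 1 gives > 100000 nM, which is a limit and not a number. Compound 2 `Cc1[nH]c(=O)n(C2CCCCC2)c1-c1ccccc1` gives 47600 nM, the higher of the two actual numbers. Compound 3 `Cc1[nH]c(=O)n(C2CCCCC2)c1-c1ccccc1OC(C)C` gives 21500 nM, the nearest value to it.

The open step leads to compound 4 `Cc1[nH]c(=O)n(C2CCCCC2)c1-c1ccc(OC(C)C)cc1`: isopropoxy in place of hydrogen on an aromatic carbon, with isopropoxy in place of hydrogen on an aromatic carbon, para to a large group. The step that bears on it is a 2.2-fold lower number from compound 2 to compound 3 (0.35 log units; beyond the scatter), where the same group enters at another aromatic carbon of that ring. The step of an at least 2.1-fold lower number from compound 1 to compound 2 (0.32 log units; beyond the scatter) concerns the aromatic nitrogen and bears on it little. The expected step is a 1.6-fold lower number from compound 2 to compound 4 (0.20 log units; within the scatter), a modest one toward a lower number. For compound 4 the estimated value is 30000 nM, with an expected range of 10000 nM to 90000 nM.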

Compound 4, half-maximal inhibitory concentration: 13000 nM
The estimate for compound 4 lay 2.3-fold (0.36 log units) above the measured number, within the range that was stated.
By their numbers in this assay, from the lowest: compounds 4 and 3 (each within the scatter of the next); then compound 2. At a limit, above all of these: compound 1.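

In this assay, isopropoxy in place of hydrogen, para to a large group, brings a 3.7-fold lower number from compound 2 to compound 4 (0.56 log units; beyond the scatter), so the lower number is not tied to the one aromatic carbon occupied in compound 3. Compound 3 and compound 4 lie within the scatter of each other, so these two places on the ring cannot be told apart. Nothing at hand gives a cause for this step.

Open, going by these compounds, is whether methoxy, an amine or a carboxylic acid at this carbon would move the number the same way. Also open, on these data alone, is whether a longer ether chain would go further.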